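The source may hold more compounds than are shown below. What is called first, only, known or untested is meant among the compounds shown, and "the series" means these compounds.

Compound 1, `CCCCCCCCc1cn([C@H]2C[C@H](O)[C@@H](CO)O2)c(=O)[nH]c1=O`, carries an octyl chain on the shared core and a sugar with a free hydroxyl and a free hydroxymethyl. Among the compounds with values here, in a functional assay on L1210 cells (Mus musculus) (on this read-out lower numbers stand for stronger inhibition and higher numbers for weaker inhibition), compound 1 gives 72 ug/mL, the only number in this set that is a number rather than a limit. Compound 2, `CCCCCCc1cn([C@H]2C[C@@H]3OP(=O)(O)OC[C@H]3O2)c(=O)[nH]c1=O`, has a hexyl chain and a sugar closed into a cyclic phosphate. In this assay compound 2 reaches only > 500 ug/mL, which is a limit of the measurement and not a number, and this is the situation described by the limit of > 500 ug/mL in this assay, at which 1 of the 2 values shown sits. Within the data shown here, no two measured compounds here differ in a single place, so no measured step is available.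

Compound 3, `CCCCCc1cn([C@H]2C[C@H](O)[C@@H](CO)O2)c(=O)[nH]c1=O`, keeps the sugar of compound 1 and differs from it by hydrogen in place of propyl on a saturated chain carbon, five bonds along the chain from an aromatic carbon. Without a measured step of the same kind, the expectation is a modest step from compound 1 toward weaker inhibition, of roughly a 2.1-fold higher number from compound 1 to compound 3 (0.32 log units; beyond the scatter), though a step within the scatter would not be surprising. Compound 3 is therefore expected to give about 150 ug/mL in this assay, within a range from 40 ug/mL to 500 ug/mL.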

Compound 3, concentration for 50% inhibition: 477 ug/mL
Beside the measured number, compound 3's estimate is 3.2-fold (0.50 log units) below it; the range from low to high includes it.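

Within the data shown here, the step in this assay is the first measured comparison in this set: with the sugar unchanged, hydrogen in place of propyl on a saturated chain carbon, five bonds along the chain from an aromatic carbon, gives a 6.6-fold higher number from compound 1 to compound 3 (0.82 log units; beyond the scatter). The outer part of the chain therefore counts for this read-out, since shortening octyl to pentyl, with no other change, moves the number beyond the usual scatter toward weaker inhibition. Compound 2 remains a limit of the assay and not a number, and it differs from compound 1 and from compound 3 in more than one place, so it adds no step: the limit of > 500 ug/mL in this assay, at which 1 of the 3 values shown sits.

Among these compounds, with only two chain lengths on this sugar giving numbers, the data cannot say whether the change with length is gradual or sudden, or whether a longer chain such as decyl would lower the number further. Also open, from the compounds shown here alone, is how a chain ending in an amine or a carboxylic acid would compare with octyl, and how the free sugar and the cyclic phosphate compare when they carry the same chain.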